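The source may hold more compounds than are shown below. What is called first, only, known or untested is meant among the compounds shown, and "the series" means these compounds.

Of the compounds shown here, three built on one shared core have been tested in a functional assay on PC-3 cells (Homo sapiens) for inhibition, read by sulforhodamine B assay, with a stated time of 48 h; a lower number here means a stronger inhibitor, a higher number a weaker inhibitor. Compound 1 `COc1cc(-c2nn(-c3cccc(NC(=O)c4cccc(C(F)(F)F)c4)c3)cc2-c2ccncc2)ccc1Cl` gives 1230 nM, compound 2 `COc1cc(-c2nn(-c3cccc(NC(=O)Nc4ccc(Cl)c(Cl)c4)c3)cc2-c2ccncc2)ccc1Cl` gives 550 nM, and compound 3 `COc1cc(-c2nn(-c3cccc(NC(=O)c4ccc(Cl)c(C(F)(F)F)c4)c3)cc2-c2ccncc2)ccc1Cl` gives 1290 nM, the highest of the three numbers; one step to it, a 1.0-fold higher number from compound 1 to compound 3 (0.02 log units; within the scatter), lies within the scatter, while the other, a 2.3-fold higher number from compound 2 to compound 3 (0.37 log units; beyond the scatter), lies beyond it. Compound 4 `COc1cc(-c2nn(-c3cccc(NC(=O)Nc4ccc(Cl)c(C(F)(F)F)c4)c3)cc2-c2ccncc2)ccc1Cl` differs from compound 3 by a single change: (4-chloro-3-(trifluoromethyl)phenyl)amino in place of 4-chloro-3-(trifluoromethyl)phenyl on a carbonyl carbon. The nearest measured parallel is a 2.2-fold lower number from compound 1 to compound 2 (0.35 log units; beyond the scatter), where an arylamino group likewise replaced an aryl group on a carbonyl carbon, though the ring substitution changed at the same time. On that basis a modest lowering is expected, a 2.2-fold lower number from compound 3 to compound 4 (0.33 log units; beyond the scatter). Compound 4 is therefore estimated at 600 nM, with a range from 300 nM to 1300 nM.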

Compound 4, half-maximal inhibitory concentration: 690 nM
Beside the measured number, compound 4's estimate is 1.2-fold (0.06 log units) below it; the measured number falls inside the stated range.
By their numbers in this assay, from the lowest: compounds 2, 4, 1 and 3 (each within the scatter of the next, the first and the last beyond it).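

With the ring held the same, a 1.9-fold lower number from compound 3 to compound 4 (0.27 log units; within the scatter) stays within the scatter in this assay, so the arylamino group on the carbonyl carbon is not separated from the aryl group here, a comparison the earlier step, which also changed the ring substitution, could not give. Likewise, a 1.3-fold higher number from compound 2 to compound 4 (0.10 log units; within the scatter) does not separate trifluoromethyl from chloro on the aromatic carbon, and a 1.8-fold lower number from compound 1 to compound 4 (0.25 log units; within the scatter) also stays within the scatter. Nothing available explains these numbers. Open, going by these compounds, is how an amine, a carboxylic acid or a longer chain in place of 4-chloro-3-(trifluoromethyl)phenyl on this carbonyl carbon would read.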